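The source may report more compounds than this note shows. Statements on the series, on what has been measured and on what is new or still open speak of the compounds shown alone.

Compound 1 `COc1cccc(C(=O)Nc2nnc(/C=C/c3cc(OC)c(OC)c(OC)c3Br)s2)c1`: 60 nM
Compound 2 `COc1ccc(C(=O)Nc2nnc(/C=C/c3cc(OC)c(OC)c(OC)c3Br)s2)cc1`: 150 nM
Compound 3 `COc1cc(/C=C/c2nnc(NC(=O)c3ccc(Cl)cc3)s2)c(Br)c(OC)c1OC`: 140 nM

All three values come from a functional assay on A549 cells (Homo sapiens) for antiproliferative activity, read by MTT assay, with a stated time of 48 h; on this read-out higher numbers stand for weaker inhibition and lower numbers for stronger inhibition. Compound 3 cannot be told apart from one of its neighbours but does stand apart from the other: the steps read a 1.1-fold lower number from compound 2 to compound 3 (0.03 log units; within the scatter) and a 2.3-fold higher number from compound 1 to compound 3 (0.37 log units; beyond the scatter).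

Compound 4 `COc1cc(/C=C/c2nnc(NC(=O)c3cccc(O)c3)s2)c(Br)c(OC)c1OC` keeps the shared core and changes only the aromatic group on the carbonyl carbon: 3-hydroxyphenyl in place of 4-chlorophenyl on a carbonyl carbon. That is 3-hydroxyphenyl in place of 4-chlorophenyl.

For the measured compounds named here, no measured step makes this exact swap, and no measured compound carries 3-hydroxyphenyl, so the evidence is indirect. The nearest comparison is compound 1, which carries 3-methoxyphenyl and gives 60 nM. Moving that methoxy group to give 4-methoxyphenyl produced a 2.5-fold higher number from compound 1 to compound 2 (0.40 log units; beyond the scatter), and the 4-chlorophenyl group produced a step of similar size. With only these three compounds, this is a thin hint that the 3-substituted ring gives the lower number. Hydroxy and methoxy have not been compared here, so only part of the gap to compound 1 is expected to carry over, giving a modest move towards a lower number in this assay, possibly no larger than the scatter.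

The expected step is a 1.6-fold lower number from compound 3 to compound 4 (0.19 log units; within the scatter).

For compound 4 the estimated value is 90 nM, with an expected range of 35 nM to 230 nM.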

Compound 4, half-maximal inhibitory concentration: 120 nM
Compound 4: middle estimate off by 1.3-fold (0.12 log units), on the low side; the range from low to high includes it.
By their numbers in this assay, from the lowest: compounds 1, 4, 3 and 2 (each within the scatter of the next, the first and the last beyond it).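

In this assay, putting 3-hydroxyphenyl on the carbonyl carbon in place of 4-chlorophenyl gives a 1.2-fold lower number from compound 3 to compound 4 (0.07 log units; within the scatter) and putting it in place of 4-methoxyphenyl gives a 1.3-fold lower number from compound 2 to compound 4 (0.10 log units; within the scatter), so compound 4 cannot be told apart from either compound. Hydrogen in place of methyl on the oxygen of the aromatic ring gives a 2.0-fold higher number from compound 1 to compound 4 (0.30 log units; within the scatter), so the hydroxy and methoxy groups at this place on the ring cannot be separated either. Compound 4 therefore lies within the scatter of all three earlier compounds, even though compound 1 stands apart from compound 2 and compound 3, which means the earlier thin hint that a 3-substituted ring gives the lower number is neither confirmed nor ruled out.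

Nothing in the data offers a reason for these small steps. From the compounds shown here alone, it remains open whether 4-hydroxyphenyl, 3-aminophenyl, 3-carboxyphenyl or 3-ethoxyphenyl on the carbonyl carbon would step beyond the scatter from compound 4 in either direction, and that comparison would show whether this position responds to the group placed on it.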